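The source may report more compounds than this note shows. Statements on the series, on what has been measured and on what is new or still open speak of the compounds shown alone.

Compound 1 `ClCc1ccc(Cn2cnc3c(Cl)ncnc32)cc1` in a functional assay on NCI-H322M cells (Homo sapiens) for cytotoxicity, read by sulforhodamine B assay, with a stated time of 48 h (a higher number here means a weaker inhibitor of growth, a lower number a stronger inhibitor of growth), gives 1820 nM. Compound 2 `ClCc1cccc(Cn2cnc3ncnc(Cl)c32)c1` has the same atoms joined differently; the difference between the two cores is not broken down here. In this assay compound 2 gives 1990 nM, which lies within the scatter of compound 1. Compound 3 `ClCc1ccc(Cn2cnc3c(Cl)nc(Cl)nc32)cc1` carries, on the core of compound 1, chloro in place of hydrogen on an aromatic carbon and in this assay compound 3 gives 12600 nM; the step is a 6.9-fold higher number from compound 1 to compound 3 (0.84 log units; beyond the scatter). Compound 4 `ClCc1cccc(Cn2cnc3nc(Cl)nc(Cl)c32)c1` carries the same change on the core of compound 2, (chloro in place of hydrogen on an aromatic carbon). Among the measured compounds shown here, the expected step is a 6.5-fold higher number from compound 2 to compound 4 (0.82 log units; beyond the scatter), set beside a 6.9-fold higher number from compound 1 to compound 3 (0.84 log units; beyond the scatter) as the single precedent, and it rests on compound 2 giving 1990 nM. Compound 4 is therefore expected to give 13000 nM in this assay, with an expected range from 5000 nM to 32000 nM.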

Compound 4, concentration for 50% growth inhibition: 14100 nM
Estimate against measurement, compound 4: 1.1-fold (0.04 log units) below; the measured number falls inside the stated range.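

On the core of compound 2, chloro in place of hydrogen on an aromatic carbon, between two ring nitrogen atoms, gives a 7.1-fold higher number from compound 2 to compound 4 (0.85 log units; beyond the scatter) in this assay. The step carries from one core to the other with no difference in size: the same change on two cores in this assay, a 6.9-fold higher number (0.84 log units; beyond the scatter) from compound 1 to compound 3 and a 7.1-fold higher number (0.85 log units; beyond the scatter) from compound 2 to compound 4, 1.0-fold (0.01 log units) apart, within the scatter of two such steps

This holds for two pairs in a single cell line and assay; it does not show that the step would hold on any other core, and it gives no reason for the shift.

Going by these compounds, what an amine, a methoxy group or a methyl group would do at this carbon stays open. Also open, on these data alone, is whether the step survives when the chloromethyl group gives way to a hydroxymethyl group.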